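A few compounds are considered here, and "the series" means these few. Any claim that something is new, unique, unknown or untested is made for them only; others in the source may bear on it.

Compound 1 `C/C(=C\c1cc(-c2ccccc2)cs1)C(N)=O` is the starting point. In a functional assay on A549 cells (Homo sapiens) for cytotoxicity, read by CCK-8 assay, with a stated time of 24 h (on this read-out higher numbers stand for weaker inhibition and lower numbers for stronger inhibition), compound 1 gives > 50000 nM, which is a limit of the assay rather than a measured number. Its relative compound 2 `C/C(=C\c1cc(-c2ccccc2C)cs1)C(N)=O` carries a methyl in place of hydrogen on an aromatic carbon, and in this assay compound 2 gives > 50000 nM, again only a limit. The step from compound 1 to compound 2 is a step that the two limits leave unreadable from compound 1 to compound 2 because of the limit of > 50000 nM in this assay, at which 2 of the 2 values shown sit. The unmeasured compound 3 `C/C(=C\c1cc(-c2ccc([N+](=O)[O-])cc2)cs1)C(N)=O` differs from compound 1 by nitro in place of hydrogen on an aromatic carbon. Going by the values given here, the single measured step that touches the same aromatic ring gives no readable size or direction, so nothing in the data points to a change beyond the scatter. Compound 3 is therefore expected to show a step of a number no higher from compound 1 to compound 3 (the limit leaves the size open). Compound 3 is estimated at 50000 nM in this assay, with an expected range from 20000 nM to 100000 nM, most likely reported again as a limit.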

Compound 3, half-maximal inhibitory concentration: 3500 nM
Compound 3: middle estimate off by 14-fold (1.15 log units), on the high side, outside the stated range (below it).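

With nitro on the six-membered aromatic ring, para to a large group, this assay gives the only readable change among the compounds shown: an at least 14-fold lower number from compound 1 to compound 3 (1.15 log units; beyond the scatter). A substituent on this ring can therefore lower the number well beyond the scatter, something the methyl of compound 2 could not show, as that step cannot be read. The step gives only a minimum size because compound 1 sits at a limit: the limit of > 50000 nM in this assay, at which 2 of the 3 values shown sit.

The compounds shown leave open whether this drop belongs to nitro itself or would also appear with an amine or a methoxy group at the same place. They also leave open whether nitro placed elsewhere on the ring would give a similar number.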